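The source may hold more compounds than are shown below. What is called first, only, known or untested is meant among the compounds shown, and "the series" means these compounds.

Working notes on the series in an ADME assay on CCRF-CEM cells (Homo sapiens) for cytotoxicity, with a stated time of 5 days; a lower number here means a stronger inhibitor, a higher number a weaker inhibitor. Compound 1 `[N-]=[N+]=N[C@H]1C[C@H](n2cnc3c(NC4CC4)nc(Cl)nc32)O[C@@H]1CO` gives only a limit, > 100000 nM. Compound 2 `CNc1nc(Cl)nc2c1ncn2[C@H]1C[C@H](N=[N+]=[N-])[C@@H](CO)O1` also gives only a limit, > 100000 nM. Compound 3 `COc1nc(Cl)nc2c1ncn2[C@H]1C[C@H](N=[N+]=[N-])[C@@H](CO)O1` likewise stands at a limit, > 100000 nM, and no number places it within the series. The whole set reads (the limit of > 100000 nM in this assay, at which 3 of the 3 values shown sit).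

The next structure is compound 4 `[N-]=[N+]=N[C@H]1C[C@H](n2cnc3c(N)nc(Cl)nc32)O[C@@H]1CO`, with amino in place of methoxy on an aromatic carbon. For the measured compounds named here, three measured steps bear on this change: a step that the two limits leave unreadable from compound 1 to compound 2, a step that the two limits leave unreadable from compound 1 to compound 3 and a step that the two limits leave unreadable from compound 2 to compound 3. The last of these is the closest, as it also has methoxy entering or leaving on an aromatic carbon, but none of the three supplies a size or a direction. Going by the values given here, nothing measured so far therefore predicts a real shift in this assay, and the most likely outcome for compound 4 is another limit. Any number that does appear could only lie on the stronger side of that limit, so the expectation leans weakly that way. The expected step is an at least 1.2-fold lower number from compound 3 to compound 4 (0.09 log units; that floor lies within the scatter), and it is a tentative estimate. For compound 4 the estimated value is 80000 nM, with an expected range from 15000 nM to 200000 nM.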

Compound 4, half-maximal inhibitory concentration: > 100000 nM
Compound 4 gave a limit, no number; the forecaster's own chance of this, stated with the estimate: 65%; at least 1.2-fold (0.09 log units) between middle value and limit.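

In this assay compound 4 gives only a limit, > 100000 nM. For the compounds shown here, no step from compound 1, compound 2 or compound 3 to compound 4 can be read, and the whole set rests at one value: the limit of > 100000 nM in this assay, at which 4 of the 4 values shown sit. The compounds shown leave open whether any substituent on that aromatic carbon gives a measurable number in this assay.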